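This account rests on a few compounds, and the source may have more. Where it says the series, first, only, none or still open, it means among the compounds named here.

Working notes on the series. The shared core is carried by compound 1 `COc1ccc(NC(=O)COc2cc(C)nc3ccc(OC)cc23)cc1` and compound 2 `COc1ccc2nc(C)cc(OCC(=O)Nc3ccc(Cl)cc3Cl)c2c1`. In a toxicity assay on HepG2 cells (Homo sapiens) for inhibition, read by CellTiter-Glo, with a stated time of 48 h (a lower number here means a stronger inhibitor, a higher number a weaker inhibitor), compound 1 gives only a limit of the assay, > 100000 nM. In this assay compound 2 likewise gives only a limit, > 100000 nM. The exchange of 4-methoxyphenyl for 2,4-dichlorophenyl on the amide-type nitrogen, a step that the two limits leave unreadable from compound 1 to compound 2, therefore has no readable size. Going by the values given here, compound 2 thus stands at the limit of the assay, and the one further value shown sits at the same place; the limit of > 100000 nM in this assay, at which 2 of the 2 values shown sit, covers both values shown.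

Compound 3 `COc1ccc2nc(C)cc(OCC(=O)Nc3cccnc3)c2c1` is the next member, not yet measured. It differs from compound 2 by pyridin-3-yl in place of 2,4-dichlorophenyl on an amide-type nitrogen. Among the compounds with values here, no measured step bears directly on this exchange: the single step known has a size that the two limits leave unreadable, and it concerns a different pair of groups. With both measured compounds at the limit, the expected step in this assay is none beyond the scatter, and a number no higher from compound 2 to compound 3 (the limit leaves the size open) is the step this expectation means. Compound 3 is estimated at 100000 nM in this assay, with a range from 40000 nM to 300000 nM, most likely again reported only as a limit.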

Compound 3, half-maximal inhibitory concentration: > 100000 nM
Compound 3 ended at the assay's limit (the forecaster's own chance of this, stated with the estimate: 85%); the middle value sits exactly at the limit.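

Compound 3 gives > 100000 nM in this assay, which is a limit of the assay and not a number. No step among compound 1, compound 2 and compound 3 can therefore be read: the limit of > 100000 nM in this assay, at which 3 of the 3 values shown sit.

The compounds shown leave open whether any group on the amide-type nitrogen would give a readable value in this assay.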